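Pyrazin-2-yl to 4-aminophenyl: expected solubility of compound 4

This account rests on a few compounds, and the source may have more. Where it says the series, first, only, none or still open, it means among the compounds named here.

In a physicochemical assay for solubility, in phosphate buffer, measured as thermodynamic solubility, at pH 7.4 (a lower number here means a less soluble compound, a higher number a more soluble compound), compound 3 `CS(=O)(=O)NC(=O)CCc1cn(-c2ccc(Br)cc2)nc1-c1cnccn1` gives 196000 nM. This lies within the scatter of compound 1 `CS(=O)(=O)NC(=O)CCc1cn(-c2ccc(Cl)cc2)nc1-c1ccc(Cl)cc1` at 100000 nM, and is clearly higher than compound 2 `CS(=O)(=O)NC(=O)CCc1cn(-c2ccc(C(F)(F)F)cc2)nc1-c1ccc(Cl)cc1` at 50000 nM.

The step under consideration leads to compound 4 `CS(=O)(=O)NC(=O)CCc1cn(-c2ccc(Br)cc2)nc1-c1ccc(N)cc1`, with 4-aminophenyl in place of pyrazin-2-yl on an aromatic carbon.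

For the measured compounds named here, the only measured step, a 2.0-fold lower number from compound 1 to compound 2 (0.30 log units; within the scatter), stays within the scatter and exchanges chloro for trifluoromethyl, not the group at this place. Going by the values given here, no measured pair isolates the present change, so the evidence is indirect. The closest guide is compound 1 at 100000 nM, which, like compound 4, has an aromatic ring of carbon only at this place, although it differs from compound 4 in other substituents.

A modest move to a lower number in this assay is therefore expected, with an estimated 2.2-fold lower number from compound 3 to compound 4 (0.34 log units; beyond the scatter). Compound 4 is estimated at 90000 nM, with an expected range of 30000 nM to 220000 nM.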

Compound 4, solubility: 160000 nM
Compound 4: the middle estimate sits 1.8-fold (0.25 log units) below what was measured, within the range that was stated.
By their numbers in this assay, from the lowest: compounds 2, 1, 4 and 3 (each within the scatter of the next, the first and the last beyond it).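

In this assay, the first step read at this place, on the aromatic carbon next to the ring nitrogen, sets 4-aminophenyl in place of pyrazin-2-yl (a 1.2-fold lower number from compound 3 to compound 4 (0.09 log units; within the scatter)). A six-membered aromatic ring with 2 hetero atoms can thus give way to a ring of carbon only bearing an amine without a shift beyond the scatter, at least with the 4-bromophenyl group held constant. No measurement available here accounts for this result.

The compounds shown hold no pair that separates the carbon-only ring from its amine, so a plain phenyl at this place, or a carboxylic acid or methoxy group in place of the amine, would be needed to tell the two apart. On these data alone, whether the same step holds with chloro or trifluoromethyl in place of the bromo substituent also stays open.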